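A few compounds are considered here, and "the series" means these few. Any claim that something is new, unique, unknown or untested is made for them only; others in the source may bear on it.

Measured so far:
- compound 1, `Oc1c(C(Nc2ccccn2)c2ccccc2F)ccc2cccnc12`: 470 nM
- compound 2, `COc1ccc(C(Nc2cc(C)ccn2)c2ccc3cccnc3c2O)cc1O`: 150 nM

Both compounds were tested in an assay for inhibition of protein disulfide-isomerase (Homo sapiens), with a stated time of 1 h; a lower number here means a stronger inhibitor, a higher number a weaker inhibitor. Compound 1 gives 470 nM, and compound 2 gives 150 nM. Of these two numbers, compound 2 has the lower one, and the gap to compound 1 is wider than the scatter of repeat measurements, so compound 2 is the stronger inhibitor of the pair.

Compound 3, `Cc1ccnc(NC(c2ccccc2F)c2ccc3cccnc3c2O)c1`, is the next compound to be measured in this assay. It shares the core of compound 2 and keeps the same ring on the nitrogen side, but the group on the saturated chain carbon is exchanged: 2-fluorophenyl in place of 3-hydroxy-4-methoxyphenyl on a saturated chain carbon bound to an aromatic carbon and a nitrogen on an aromatic ring. In plain terms, the oxygen-bearing ring of compound 2 is replaced by the fluorine-bearing ring that compound 1 carries. Going by the values given here, compound 1 and compound 2 differ in two places at once, so no single step isolates this exchange; what is known is only that compound 1, with the fluorine-bearing ring, sits at the weaker end.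

For compound 3 the expected step is a 2.3-fold higher number from compound 2 to compound 3 (0.37 log units; beyond the scatter), a loss of potency that may reach beyond the scatter. Compound 3 is estimated at 350 nM, with a range from 120 nM to 1000 nM.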

Compound 3, half-maximal inhibitory concentration: 880 nM
Estimate against measurement, compound 3: 2.5-fold (0.40 log units) below; low and high end bracket the measured number.
By their numbers in this assay, from the lowest: compound 2; then compounds 1 and 3 (each within the scatter of the next).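

In this assay the exchange of 3-hydroxy-4-methoxyphenyl for 2-fluorophenyl on the saturated chain carbon can now be read as a single change, and it costs potency: the step is a 5.9-fold higher number from compound 2 to compound 3 (0.77 log units; beyond the scatter) and shows that the group at this position matters to the number. The other single change, methyl in place of hydrogen on an aromatic carbon, gives a 1.9-fold higher number from compound 1 to compound 3 (0.27 log units; within the scatter) with the 2-fluorophenyl group in place, so this methyl cannot be told apart from no change at all. Nothing given here says why the ring exchange lowers potency.

The exchange swaps several features at once, as the ring that leaves carries a hydroxyl and a methoxy group while the ring that enters carries a fluorine, so the compounds shown cannot say which of these accounts for the step; a plain phenyl ring or a 3-hydroxyphenyl ring at this position would separate them. On these data alone, whether the methyl stays just as silent alongside the 3-hydroxy-4-methoxyphenyl group also remains open.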